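A few compounds are considered here, and "the series" means these few. Any claim that something is new, unique, unknown or untested is made for them only; others in the source may bear on it.

Among the compounds with values here, in a functional assay on U-251 cells (Homo sapiens) for cytotoxicity (a lower number here means a stronger inhibitor of growth, a higher number a weaker inhibitor of growth), compound 2 `CSc1ccc(C2=C(c3ccc(F)c(C)c3)C(=O)N3CCCC3C2)cc1` gives 200 nM, the lower of the two numbers measured so far, while compound 1 `CSc1ccc(C2=C(c3ccc(F)c(F)c3)C(=O)N3CCCC3C2)cc1` gives 15000 nM. Compound 3 `COc1ccc(C2=C(c3ccc(SC)cc3)CC3CCCN3C2=O)cc1` differs from compound 2 at one place: 4-methoxyphenyl in place of 4-fluoro-3-methylphenyl on a double-bonded ring carbon. Within the data shown here, the one measured step, a 75-fold lower number from compound 1 to compound 2 (1.88 log units; beyond the scatter), altered the group on this same carbon and was large, so a sizeable move is plausible here, although that step tested only a methyl for a fluoro. A higher number is expected, with an estimated 5.0-fold higher number from compound 2 to compound 3 (0.70 log units; beyond the scatter). The expected value for compound 3 is 1000 nM, with an estimated range of 150 nM to 7000 nM.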

Compound 3, concentration for 50% growth inhibition: 2000 nM
The estimate for compound 3 lay 2.0-fold (0.30 log units) below the measured number; the range from low to high includes it.
By their numbers in this assay, from the lowest: compound 2; then compound 3; then compound 1.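

In this assay, the change to 4-methoxyphenyl gave a 10-fold higher number from compound 2 to compound 3 (1.00 log units; beyond the scatter) and so showed that this double-bonded ring carbon responds to an exchange of the whole aryl group, not only to methyl in place of fluoro. The same group gave a 7.5-fold lower number from compound 1 to compound 3 (0.88 log units; beyond the scatter) when set against 3,4-difluorophenyl, so its number falls inside the span set by the two earlier groups. No available evidence accounts for either step.

Open, as far as these compounds go, is how an amine or a carboxylic acid on this phenyl ring would fare. Also open, from the compounds shown here alone, is whether ethoxy, a longer chain than methoxy, would keep the number of compound 3.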